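This account rests on a few compounds, and the source may have more. Where it says the series, first, only, none or still open, it means among the compounds named here.

Compound 1 `CN(C)CCn1c(=O)c(=Cc2ccc(O)cc2)s/c1=C1\C(=O)Nc2ccc(F)cc21` is the reference point of this set. In a functional assay on HT-29 cells (Homo sapiens) for inhibition, read by MTT assay, with a stated time of 72 h (on this read-out higher numbers stand for weaker inhibition and lower numbers for stronger inhibition), compound 1 gives 1480 nM, the second highest of the three numbers recorded. Compound 2 `CN(C)CCn1c(=O)c(=Cc2ccc(O)cc2)s/c1=C1\C(=O)Nc2ccc(Br)cc21` gives 1920 nM, and the step of a 1.3-fold higher number from compound 1 to compound 2 (0.11 log units; within the scatter). Going by the values given here, compound 3 `CCN(CC)CCCn1c(=O)c(=Cc2ccc(O)cc2)s/c1=C1\C(=O)Nc2ccc(C)cc21` gives 770 nM; no single-point step to compound 1 exists, so the two values stand side by side within the scatter.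

Compound 4 `CN(C)CCn1c(=O)c(=Cc2ccc(F)c(F)c2)s/c1=C1\C(=O)Nc2ccc(F)cc21` differs from compound 1 as follows: 3,4-difluorophenyl in place of 4-hydroxyphenyl on a double-bonded chain carbon bound to an aromatic carbon. Among the compounds with values here, none of the measured steps touches this position, so no step in the set bears on the change, and its direction cannot be read from the data. The estimate for compound 4 is therefore centred near compound 1 with a wide range: 2200 nM (600 nM to 8000 nM), meaning an expected step of a 1.5-fold higher number from compound 1 to compound 4 (0.17 log units; within the scatter).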

Compound 4, half-maximal inhibitory concentration: 3090 nM
For compound 4 the middle estimate is 1.4-fold (0.15 log units) below the measured one; measured number inside the range.
By their numbers in this assay, from the lowest: compounds 3, 1, 2 and 4 (each within the scatter of the next, the first and the last beyond it).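

In this assay, going by these compounds alone, 3,4-difluorophenyl in place of 4-hydroxyphenyl on a double-bonded chain carbon bound to an aromatic carbon gives a 2.1-fold higher number from compound 1 to compound 4 (0.32 log units; beyond the scatter), the first step at this position and the first in the set beyond the scatter. The position therefore responds to change, though modestly, and the hydroxyl is not required for activity in the low micromolar range. No measured evidence accounts for the step. From the compounds shown here alone, it remains open how a 4-aminophenyl or 4-methoxyphenyl group would read at this position. A single fluorine on the phenyl would help separate the loss of the hydroxyl from the entry of the two fluorines.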